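Oral exposure notes: pyridyl ether swap in the series

The source may report more compounds than this note shows. Statements on the series, on what has been measured and on what is new or still open speak of the compounds shown alone.

Measured in an ADME assay on the whole organism (Rattus norvegicus) for pharmacokinetics, using cassette dosing, at a dose of 1 mg/kg by the oral route; a lower number here means that a smaller share of the oral dose reaches the circulation, a higher number that a larger share of the oral dose reaches the circulation:
- compound 1 `Cc1ccc(Cn2c(=O)n(C[C@H](C)C(=O)O)c(=O)[nH]/c2=N\c2ccc(OC(C)C)c(Cl)c2)cc1`: 73.1%
- compound 2 `C[C@@H](Cn1c(=O)[nH]/c(=N\c2ccc(Oc3cncc(F)c3)cc2)n(Cc2ccc(Cl)cc2)c1=O)C(=O)O`: 74.3%
- compound 3 `Cc1cc(/N=c2\[nH]c(=O)n(C[C@H](C)C(=O)O)c(=O)n2Cc2ccc(Cl)cc2)ccc1OC(C)C`: 102%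

Compound 2 sits with compound 1 inside the usual scatter, so the two cannot be told apart; compound 3 lies above compound 2 by a gap beyond the scatter. Compound 4 `C[C@@H](Cn1c(=O)[nH]/c(=N\c2ccc(Oc3ccc(F)cn3)cc2)n(Cc2ccc(Cl)cc2)c1=O)C(=O)O` is not yet measured. It differs from compound 2 only in the ether-linked ring: 5-fluoropyridin-2-yl in place of 5-fluoropyridin-3-yl on an oxygen on an aromatic ring. Among the compounds with values here, the three measured compounds differ from one another in several places at once, so no single-change step is available to calibrate this swap. The expectation is therefore no step beyond the scatter in this assay, in either direction. Compound 4 is estimated at 70%, within 45% to 95%. The expected step is a number 4.3 percentage points lower from compound 2 to compound 4 (within the scatter).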

Compound 4, oral bioavailability: 82.4%
Compound 4: the middle estimate sits 12.4 percentage points below what was measured; the measured number falls inside the stated range.
By their numbers in this assay, from the lowest: compounds 1, 2 and 4 (each within the scatter of the next); then compound 3.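

In this assay, within the data shown here, 5-fluoropyridin-2-yl in place of 5-fluoropyridin-3-yl on an oxygen on an aromatic ring gives a number 8.1 percentage points higher from compound 2 to compound 4 (within the scatter) as the first single-change step in this set. Oral bioavailability therefore does not separate these two pyridyl ethers, and this position accepts the swap without a step beyond the scatter. Nothing available accounts for the step.

Still open, going by these compounds, is whether an amine or a methoxy group in place of the fluorine keeps oral bioavailability in this range. Also open, on these data alone, is whether the same swap behaves alike with the other groups on the shared core.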